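Methoxy addition to compound 1 in the growth assay

The source may report more compounds than this note shows. Statements on the series, on what has been measured and on what is new or still open speak of the compounds shown alone.

Measured in a functional assay on MCF7 cells (Homo sapiens) for cytotoxicity, read by sulforhodamine B assay, with a stated time of 48 h; on this read-out lower numbers stand for stronger inhibition of growth and higher numbers for weaker inhibition of growth:
compound 1 `COc1ccc(/C(Cl)=C/C=C(\C#N)C(=O)c2c[nH]c3ccc(Br)cc23)cc1`: > 100000 nM, a limit of the assay.
compound 2 `COc1ccc(/C(Cl)=C/C=C(\C#N)C(=O)c2c[nH]c3ccccc23)cc1`: > 100000 nM, a limit of the assay.
compound 3 `COc1ccc(/C(Cl)=C/C=C(\C#N)C(=O)c2c[nH]c3ccc(OC)cc23)cc1`: > 100000 nM, a limit of the assay.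

Compound 1 stands at the limit of > 100000 nM in this assay, at which 3 of the 3 values shown sit; no number places it within the series, only the limit. The three steps between measured compounds, a step that the two limits leave unreadable from compound 1 to compound 2, a step that the two limits leave unreadable from compound 1 to compound 3 and a step that the two limits leave unreadable from compound 2 to compound 3, are all bounded on both sides by that limit, so none of them has a readable size or direction.

Compound 4 `COc1ccc(/C(Cl)=C/C=C(\C#N)C(=O)c2c[nH]c3ccc(Br)cc23)cc1OC` differs from compound 1 by methoxy in place of hydrogen on an aromatic carbon. Going by the values given here, the one measured step of the same kind, a step that the two limits leave unreadable from compound 2 to compound 3, lies at a different place on the shared core and is itself unreadable, so it gives no size to carry over. With every measured value sitting at the limit, the expectation for compound 4 in this assay is no readable step beyond the scatter, and the step that the limit leaves unreadable from compound 1 to compound 4 is an estimate that rests only on the three limits. Compound 4 is therefore estimated at 150000 nM, with a range from 50000 nM to 500000 nM, most likely reported as a limit again.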

Compound 4, concentration for total growth inhibition: > 100000 nM
Compound 4: only a limit was reported; the forecaster's own chance of this, stated with the estimate: 85%; the middle value is on the limit's open side.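

In this assay compound 4 gives > 100000 nM, a limit of the assay, so no step from compound 1 to compound 4 can be read: the limit of > 100000 nM in this assay, at which 4 of the 4 values shown sit.

The compounds shown leave open whether any change to the shared core brings growth inhibition into the measurable range.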